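Three limit-bound analogues and a difluorophenyl candidate

This account rests on a few compounds, and the source may have more. Where it says the series, first, only, none or still open, it means among the compounds named here.

Measured so far, all in a functional assay on T47D cells (Homo sapiens) for inhibition, read by sulforhodamine B assay, with a stated time of 48 h; on this read-out higher numbers stand for lower toxicity in this test and lower numbers for higher toxicity in this test:
compound 1, `COc1cc(-c2cc(/C=C/C(=O)c3ccc(N)cc3)[nH]n2)cc(OC)c1OC`: > 100000 nM
compound 2, `COc1ccc(C(=O)/C=C/c2cc(-c3cc(OC)c(OC)c(OC)c3)n[nH]2)cc1OC`: > 100000 nM
compound 3, `COc1ccc(C(=O)/C=C/c2cc(-c3cc(OC)c(OC)c(OC)c3)n[nH]2)cc1`: > 100000 nM

Each of these values is a limit of this assay, not a number; all three sit at the limit of > 100000 nM in this assay, at which 3 of the 3 values shown sit. Compound 3 therefore stands only at a limit, and the two further values shown are limits as well. The steps between the measured compounds cannot be read: a step that the two limits leave unreadable from compound 1 to compound 2, a step that the two limits leave unreadable from compound 1 to compound 3 and a step that the two limits leave unreadable from compound 2 to compound 3 all lie between two limits, so their size is not known.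

Compound 4, `COc1cc(-c2cc(/C=C/C(=O)c3ccc(F)c(F)c3)[nH]n2)cc(OC)c1OC`, is not yet measured. It differs from compound 3 by 3,4-difluorophenyl in place of 4-methoxyphenyl on a carbonyl carbon. Within the data shown here, the steps that bear on this position are the ones changing the same aryl group on the carbonyl carbon, from compound 1 to compound 2 and from compound 2 to compound 3, and both are unreadable. Among the measured compounds shown here, no measured step gives a direction, so no step beyond the scatter is expected in this assay; the working expectation is that compound 4 again ends at the limit.

Compound 4 is estimated at 100000 nM, with a range from 20000 nM to 300000 nM, which means an expected step of a number no higher from compound 3 to compound 4 (the limit leaves the size open).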

Compound 4, concentration lethal to 50% of the cells: > 100000 nM
Compound 4 gave a limit, no number; the forecaster's own chance of this, stated with the estimate: 75%; the middle value lies on the limit itself.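

From the compounds shown here alone, no new step can be read in this assay: the steps joining compound 4 to compound 1, compound 2 and compound 3 all lie between two limits, and their size stays unknown. The compounds shown leave open whether any aryl group on the carbonyl carbon would give a number rather than a limit, with every value so far at one point: the limit of > 100000 nM in this assay, at which 4 of the 4 values shown sit.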